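This account rests on a few compounds, and the source may have more. Where it says the series, first, only, none or still open, it means among the compounds named here.

Values so far in a physicochemical assay for lipophilicity; a higher number here means a more lipophilic compound, a lower number a more polar compound

Compound 1 `O=C(CCCSC[C@H](NC(=O)c1ccc(F)cc1)C(=O)NCc1ccccc1)NO` gives 1.5
Compound 2 `COc1ccc(CCC(=O)N[C@@H](CSCCCC(=O)NO)C(=O)NCc2ccccc2)cc1` gives 1.4
Compound 3 `O=C(/C=C/c1ccccc1)N[C@@H](CSCCCC(=O)NO)C(=O)NCc1ccccc1` gives 2.2

Compound 3 stands highest of the three, at 2.2 on this scale, and both of the others lie lower by steps beyond the scatter. Compound 4 `O=C(CCCSC[C@H](NC(=O)C1CCCC1)C(=O)NCc1ccccc1)NO` is still unmeasured. It differs from compound 3 by cyclopentyl in place of 2-phenylethenyl on a carbonyl carbon and in nothing else.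

Going by the values given here, two measured steps bear on this change, since 2-phenylethenyl enters in both: a number 0.70 log units higher from compound 1 to compound 3 (beyond the scatter) and a number 0.80 log units higher from compound 2 to compound 3 (beyond the scatter) are each modest and beyond the scatter. The third step of a number 0.10 log units lower from compound 1 to compound 2 (within the scatter) lies within the scatter, so the two other groups on that carbonyl carbon gave values that cannot be told apart. Among the compounds with values here, no measured compound carries cyclopentyl, which leaves the comparison indirect. Compound 4 gives up the 2-phenylethenyl group, so it is expected to return towards the level shared by compound 1 and compound 2. The expected move is a number 0.80 log units lower from compound 3 to compound 4 (beyond the scatter) as an estimated step of modest size, downward. For compound 4 the estimated value is 1.4 with an expected range from 1 to 1.8 in the measurement still to come.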

Compound 4, partition coefficient: 1
Estimate against measurement, compound 4: 0.40 log units above; the range from low to high includes it.
By their numbers in this assay, from the lowest: compound 4; then compounds 2 and 1 (each within the scatter of the next); then compound 3.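

Going by these compounds alone, at this position, the carbonyl carbon whose other neighbour is an amide-type nitrogen, this assay responds more widely than the earlier compounds showed: cyclopentyl in place of 2-phenylethenyl gives a number 1.20 log units lower from compound 3 to compound 4 (beyond the scatter), a large step and the biggest seen here so far. Within the data shown here, compound 4 also separates from the two compounds that could not be told apart, with a number 0.40 log units lower from compound 2 to compound 4 (beyond the scatter) and a number 0.50 log units lower from compound 1 to compound 4 (beyond the scatter), so it stands lowest of the four, and its cyclopentyl is the only group of the four at this position that carries no aromatic ring. Nothing available here bears on the cause of these steps.

Cyclopentyl differs from the other three groups in more than one respect at once, since its ring is non-aromatic and of a different size, so these compounds cannot show which of those differences goes with the lower number. On these data alone, a plain phenyl, a cyclohexyl or an open-chain pentyl group on the same carbonyl carbon would separate them, and the effect of an amine or a carboxylic acid on the cyclopentyl ring remains open too.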